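The compounds below may be only part of what the source reports. "The series", "measured", "known", "first", "only" and "open" are said of these compounds alone.

Of the compounds shown here, three sharing one core have been measured in a functional assay on MDA-MB-435 cells (Homo sapiens) for antiproliferative activity, read by MTT assay, with a stated time of 5 days; on this read-out lower numbers stand for stronger inhibition and higher numbers for weaker inhibition. Compound 1 `COc1cc[nH]c1/C=C1\C(=O)Nc2ccc([N+](=O)[O-])c(N3CC[C@H](O)C3)c21` gives 104 nM, compound 2 `COc1cc[nH]c1/C=C1\C(=O)Nc2ccc([N+](=O)[O-])cc21` gives 7460 nM, and compound 3 `COc1cc[nH]c1/C=C1\C(=O)Nc2ccc([N+](=O)[O-])c(N[C@H]3CC[C@H](O)CC3)c21` gives 8550 nM. Compound 3 thus sits at the weak end of the set: its number lies close to that of compound 2, a 1.1-fold higher number from compound 2 to compound 3 (0.06 log units; within the scatter), while the gap to compound 1 is large, an 82-fold higher number from compound 1 to compound 3 (1.91 log units; beyond the scatter).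

Compound 4 `COc1cc[nH]c1/C=C1\C(=O)Nc2ccc([N+](=O)[O-])c(N3CCC(O)CC3)c21` differs from compound 3 in one place: 4-hydroxypiperidin-1-yl in place of (4-hydroxycyclohexyl)amino on an aromatic carbon. For the measured compounds named here, two measured steps bear on this change. Both a 72-fold higher number from compound 1 to compound 2 (1.86 log units; beyond the scatter) and an 82-fold higher number from compound 1 to compound 3 (1.91 log units; beyond the scatter) show that a hydroxylated ring containing a nitrogen atom, as in compound 1, gives a far lower number in this assay than either hydrogen or an amino group bearing a ring of carbon only. Compound 4 carries such a nitrogen-containing ring, so a large fall in this assay is expected, a 29-fold lower number from compound 3 to compound 4 (1.45 log units; beyond the scatter). Compound 4 is therefore estimated at 300 nM, with a likely range from 70 nM to 1500 nM.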

Compound 4, half-maximal inhibitory concentration: 46 nM
Compound 4: middle estimate off by 6.5-fold (0.81 log units), on the high side, and the stated range ends above it.
By their numbers in this assay, from the lowest: compound 4; then compound 1; then compounds 2 and 3 (each within the scatter of the next).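

On the aromatic carbon ortho to a nitro group, the identity of the group matters far more than the mere presence of a hydroxylated ring: in this assay, 4-hydroxypiperidin-1-yl in place of (4-hydroxycyclohexyl)amino gives a 190-fold lower number from compound 3 to compound 4 (2.27 log units; beyond the scatter), and in place of hydrogen it gives a 160-fold lower number from compound 2 to compound 4 (2.21 log units; beyond the scatter). The low number of compound 1 is thus not unique to 3-hydroxypyrrolidin-1-yl, and the 4-hydroxypiperidin-1-yl group goes modestly further, with a 2.3-fold lower number from compound 1 to compound 4 (0.35 log units; beyond the scatter). Nothing measured here explains why these two groups differ so sharply from (4-hydroxycyclohexyl)amino.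

On these data alone, what plain piperidin-1-yl, morpholin-4-yl or piperazin-1-yl would give at this position stays open, which leaves the part played by the hydroxyl unsettled. Also open, as far as these compounds go, is whether an open-chain group such as dimethylamino could match these rings.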